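The source may hold more compounds than are shown below. What is called first, only, known or untested is meant among the compounds shown, and "the series" means these compounds.

Measured in an ADME assay on LLC-MK2 cells (Macaca mulatta) for cytotoxicity, read by MTT assay, with a stated time of 48 h; on this read-out lower numbers stand for higher toxicity in this test and higher numbers for lower toxicity in this test:
- compound 1 `C/C(=C\c1ccccc1)C(=O)/C=C/c1ccc([N+](=O)[O-])cc1`: 43300 nM
- compound 2 `COc1ccc(/C=C(\C)C(=O)/C=C/c2ccc([N+](=O)[O-])cc2)cc1`: 20100 nM
- compound 3 `COc1ccc(/C=C/C(=O)/C(C)=C/c2ccc([N+](=O)[O-])cc2)cc1`: 172000 nM

Of these three, compound 3 carries the highest number, and its gaps to the other two lie beyond the usual scatter. It therefore stands as the least toxic of the set in this assay. The next compound to be tested is compound 4 `C/C(=C\c1ccc([N+](=O)[O-])cc1)C(=O)/C=C/c1ccc([N+](=O)[O-])cc1`, which has nitro in place of methoxy on an aromatic carbon, para to a large group: nitro in place of methoxy on an aromatic carbon.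

Among the compounds with values here, no measured pair makes this exchange. Within the data shown here, the only single-place step is a 2.2-fold lower number from compound 1 to compound 2 (0.33 log units; beyond the scatter), a modest change where methoxy replaced hydrogen on an aromatic carbon, so it offers only indirect guidance. Taken alone, that step hints that losing methoxy might raise the number. However, compound 3 already lies well above compound 1 at 43300 nM, so a moderate move to a lower number seems more likely. The expected change is a 3.4-fold lower number from compound 3 to compound 4 (0.54 log units; beyond the scatter). For compound 4 the estimate is 50000 nM, with an expected range from 15000 nM to 150000 nM.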

Compound 4, half-maximal cytotoxic concentration: 32500 nM
Estimate against measurement, compound 4: 1.5-fold (0.19 log units) above; low and high end bracket the measured number.
By their numbers in this assay, from the lowest: compounds 2, 4 and 1 (each within the scatter of the next, the first and the last beyond it); then compound 3.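

In this assay, nitro in place of methoxy on an aromatic carbon gives a 5.3-fold lower number from compound 3 to compound 4 (0.72 log units; beyond the scatter) but gives a 1.6-fold higher number from compound 2 to compound 4 (0.21 log units; within the scatter) as well, so the same exchange has an effect beyond the scatter in one case and none that can be read in the other. Within the data shown here, its outcome therefore depends on which compound it starts from, something no earlier pair could show. Nitro in place of hydrogen gives a 1.3-fold lower number from compound 1 to compound 4 (0.12 log units; within the scatter) and stays within the scatter, so compound 4 keeps a number not distinguishable from that of compound 1. Nothing available accounts for the contrast between the two methoxy exchanges. The compounds shown leave open whether an amine or a carboxylic acid on this aromatic carbon would stay within the scatter of these numbers. They also leave open whether a chloro group would behave like nitro or methoxy.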